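The source may hold more compounds than are shown below. What is called first, only, known or untested is meant among the compounds shown, and "the series" means these compounds.

Compound 1 `Cc1ncc([N+](=O)[O-])n1CC(O)CSC(=S)N1CCN(c2ccccc2)CC1`: > 5000000 nM (a limit)
Compound 2 `Cc1ncc([N+](=O)[O-])n1CC(O)CSC(=S)N1CCCC1`: 1340000 nM
Compound 3 `Cc1ncc([N+](=O)[O-])n1CC(O)CSC(=S)N1CCN(C(=O)OC(C)(C)C)CC1`: not yet measured

Both values come from a toxicity assay on HeLa cells (Homo sapiens) for cytotoxicity, read by MTT assay, with a stated time of 24 h; on this read-out higher numbers stand for weaker inhibition and lower numbers for stronger inhibition. For compound 1, the reading of > 5000000 nM is a limit of the assay and not a number. Compound 1 therefore stands at the limit of > 5000000 nM in this assay, at which 1 of the 2 values shown sits. Compound 2 gives an actual number in this assay, 1340000 nM.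

Compound 3 keeps the core of compound 1 and changes one group: tert-butoxycarbonyl in place of phenyl on an amine nitrogen in a ring. Within the data shown here, no measured pair of compounds shows what this exchange does, so any forecast rests on very little. Compound 2 stands at 1340000 nM. A number not far below the limit seems possible for compound 3, though it could also return only a limit. A modest move toward lower numbers in this assay is expected, possibly none beyond the scatter, and the estimated change is an at least 1.6-fold lower number from compound 1 to compound 3 (0.22 log units; that floor lies within the scatter). For compound 3 the expected value is 3000000 nM, with an estimated range from 1000000 nM to 8000000 nM.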

Compound 3, half-maximal inhibitory concentration: 689000 nM
Beside the measured number, compound 3's estimate is 4.4-fold (0.64 log units) above it; the whole stated range lies above it.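

In this assay, putting tert-butoxycarbonyl in place of phenyl on the amine nitrogen in the ring gives an at least 7.2-fold lower number from compound 1 to compound 3 (0.86 log units; beyond the scatter). Among these compounds, the earlier compounds offered no measured step, so this is the first sign that the group on this nitrogen can change the reading by more than the usual scatter, here toward stronger inhibition of the cells. The true size of the step remains unknown because compound 1 gives a limit of the assay and not a number: the limit of > 5000000 nM in this assay, at which 1 of the 3 values shown sits.

The exchange removes a six-membered aromatic ring of carbon only and brings in a group with no ring, a double bond outside aromatic rings and hydrogen-bond acceptors, and this single step cannot show which of these differences matters, or whether any of them does. A small acetyl group, a benzyl group or a free amine hydrogen on the same nitrogen would help separate these differences, and such compounds would show whether the loss of phenyl or the arrival of tert-butoxycarbonyl drives the step.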